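The source may hold more compounds than are shown below. What is called first, only, known or untested is meant among the compounds shown, and "the series" means these compounds.

Measured compounds:
- Compound 1, `O=C(O)CCCC(=O)N1CCC(NS(=O)(=O)c2cc(S(=O)(=O)c3ccccc3)ccc2C(F)(F)F)CC1`: 500 nM
- Compound 2, `CC(C)(C)OC(=O)N1CC[C@@H](C(=O)N2CCC(NS(=O)(=O)c3cc(S(=O)(=O)c4ccccc4)ccc3C(F)(F)F)CC2)C1`: 50 nM

Both compounds were tested in an assay on isolated protein for displacement of a labelled ligand from secreted frizzled-related protein 1 (Homo sapiens), read by fluorescence polarization, with a stated time of 30 min; on this read-out lower numbers stand for stronger inhibition and higher numbers for weaker inhibition. Compound 2 stands at the lower of the two numbers; the step between them is a 10-fold lower number from compound 1 to compound 2 (1.00 log units; beyond the scatter). That single step exchanged the whole group on the carbonyl carbon, a 3-carboxypropyl chain for a 1-(tert-butoxycarbonyl)pyrrolidin-3-yl ring, so it changed more than one feature at once.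

Compound 3, `O=C([C@@H]1CCNC1)N1CCC(NS(=O)(=O)c2cc(S(=O)(=O)c3ccccc3)ccc2C(F)(F)F)CC1`, keeps the ring of compound 2 but differs by hydrogen in place of tert-butoxycarbonyl on an amine nitrogen in a ring. Among the measured compounds shown here, no measured step touches this amine nitrogen on its own, so the one step available speaks only indirectly: it shows that the region on the carbonyl carbon can move the number by a modest amount. Without a direct comparison, the expected step is taken as a 3.0-fold higher number from compound 2 to compound 3 (0.48 log units; beyond the scatter), a weakening of modest size that stays close to the scatter. Compound 3 is therefore estimated at 150 nM in this assay, with a range from 40 nM to 600 nM.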

Compound 3, half-maximal inhibitory concentration: 60 nM
Beside the measured number, compound 3's estimate is 2.5-fold (0.40 log units) above it, within the range that was stated.
By their numbers in this assay, from the lowest: compounds 2 and 3 (each within the scatter of the next); then compound 1.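

In this assay, taking tert-butoxycarbonyl off the amine nitrogen of the five-membered ring gives a 1.2-fold higher number from compound 2 to compound 3 (0.08 log units; within the scatter), so compound 2 and compound 3 cannot be told apart, even though this change removes a group of 7 heavy atoms and leaves only a hydrogen. The comparison with the open chain adds a second point: pyrrolidin-3-yl in place of 3-carboxypropyl gives an 8.3-fold lower number from compound 1 to compound 3 (0.92 log units; beyond the scatter), which shows that, for these compounds, the lower number seen with the ring on the carbonyl carbon does not depend on tert-butoxycarbonyl being present. Nothing measured here offers a reason for either step.

The step away from compound 1 swaps a chain ending in a carboxylic acid for a ring bearing an amine, so these compounds cannot say whether the ring, the loss of the acid or the presence of the amine matters, a question that a plain butyl chain on the carbonyl carbon could help to separate. From the compounds shown here alone, it also remains open how groups of intermediate size on the ring nitrogen, such as methyl or acetyl, would compare with hydrogen and tert-butoxycarbonyl.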